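Oxime ether acids: shortening the acid arm in compound 3

The source may hold more compounds than are shown below. What is called first, only, known or untested is meant among the compounds shown, and "the series" means these compounds.

Two oxime ether acids sharing one core have been measured. Compound 1 `C/C(CCCC(=O)O)=N\OC(c1ccc(OCc2ccc3ccccc3n2)cc1)C1CCCCC1` gives 59 nM in a functional assay for inhibition of Polyunsaturated fatty acid 5-lipoxygenase (Homo sapiens); on this read-out higher numbers stand for weaker inhibition and lower numbers for stronger inhibition. Compound 2 `O=C(O)C1CCC(=NOC(c2ccc(OCc3ccc4ccccc4n3)cc2)C2CCCCC2)CC1` gives 67 nM in this assay, the higher of the two numbers, though the step of a 1.1-fold higher number from compound 1 to compound 2 (0.06 log units; within the scatter) is within the scatter and so tells nothing about order. Compound 3 `O=C(O)/C=N/OCC(c1ccc(OCc2ccc3ccccc3n2)cc1)C1CCCCC1` carries the change (a group of 7 heavy atoms (3 carbon, 1 nitrogen, 3 oxygen; no ring) in place of a group of 11 heavy atoms (7 carbon, 1 nitrogen, 3 oxygen; one six-membered non-aromatic ring of carbon only), on a saturated chain carbon bound to an aromatic carbon and a saturated ring carbon). Among the measured compounds shown here, the one measured step, a 1.1-fold higher number from compound 1 to compound 2 (0.06 log units; within the scatter), concerns a swap of the acid-bearing arm at the oxime oxygen and was flat; the change to compound 3 is larger, cutting the acid arm back and inserting a chain carbon before the oxime oxygen, and no step of that kind has been measured. For compound 3 a somewhat weaker inhibition is expected, a step of a 2.4-fold higher number from compound 2 to compound 3 (0.38 log units; beyond the scatter), with wide uncertainty. Compound 3 is estimated at 160 nM in this assay, within 35 nM to 750 nM.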

Compound 3, half-maximal inhibitory concentration: 47 nM
For compound 3 the middle estimate is 3.4-fold (0.53 log units) above the measured one; the measured number falls inside the stated range.
By their numbers in this assay, from the lowest: compounds 3, 1 and 2 (each within the scatter of the next).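

At the saturated chain carbon bound to an aromatic carbon and a saturated ring carbon, the read-out in this assay stays flat through a much larger change than the earlier pair covered: a 1.4-fold lower number from compound 2 to compound 3 (0.15 log units; within the scatter) and a 1.3-fold lower number from compound 1 to compound 3 (0.10 log units; within the scatter). The group of 7 heavy atoms with no ring therefore cannot be told apart on this read-out from the group of 11 heavy atoms with one six-membered non-aromatic ring of carbon only, or from the group of 10 heavy atoms with no ring. Nothing at hand offers a reason for this flatness.

As far as these compounds go, all three compounds end in a carboxylic acid, so how a primary amide or a methyl ester in its place would read stays open. Also open, from the compounds shown here alone, is how a longer chain between the oxime and the acid would read.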